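Removing the carbamoylmethyl side chain: compound 3 to compound 4

A few compounds are considered here, and "the series" means these few. Any claim that something is new, unique, unknown or untested is made for them only; others in the source may bear on it.

Compound 1, `O=C(O)[C@@H]1CCCN1C(=O)CN(c1nc(Cl)nc2[nH]cnc12)C1CC1`: 34.9%
Compound 2, `N=C(N)NCCC[C@H](NC(=O)CN(c1ncnc2c1ncn2C1CCCCO1)C1CC1)C(=O)OCc1ccccc1`: 52.4%
Compound 3, `NC(=O)CC[C@H](NC(=O)CN(c1ncnc2c1ncn2C1CCCCO1)C1CC1)C(=O)OCc1ccccc1`: 39.4%

In a functional assay on the whole organism (Tail, strain ICR) with Mus musculus as the target, in the tail flick test, with a stated time of 60 min, at a dose of 25 umol/kg by the oral route (on this read-out higher numbers stand for a stronger effect at the one dose given and lower numbers for a weaker effect), compound 3 gives 39.4%, which stands second of the three numbers: compound 1 lies within the scatter of it, while compound 2 is separated from it by a step beyond the scatter, a number 13 percentage points lower from compound 2 to compound 3 (beyond the scatter). Compound 4, `C[C@H](NC(=O)CN(c1ncnc2c1ncn2C1CCCCO1)C1CC1)C(=O)OCc1ccccc1`, differs from compound 3 by hydrogen in place of carbamoylmethyl on a saturated chain carbon, two bonds along the chain from an amide-type nitrogen and a carbonyl carbon. Going by the values given here, the only measured step, from compound 2 to compound 3, exchanged one side chain for another rather than removing it, so no step bears directly on this change. Compound 4 is therefore expected to show no step beyond the scatter, a number 4.4 percentage points lower from compound 3 to compound 4 (within the scatter), and its estimated value is 35% with a range from 20% to 50%.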

Compound 4, a percentage reported as activity, at one dose (the size of the read-out at that dose, not a potency): 53%
Beside the measured number, compound 4's estimate is 18 percentage points below it, and the stated range ends below it.
By their numbers in this assay, from the lowest: compounds 1 and 3 (each within the scatter of the next); then compounds 2 and 4 (each within the scatter of the next).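

In this assay, the carbamoylmethyl side chain proves dispensable at this position: hydrogen in its place gives a number 13.6 percentage points higher from compound 3 to compound 4 (beyond the scatter). The group of compound 2 and hydrogen give numbers within the scatter of each other, a number 0.6 percentage points higher from compound 2 to compound 4 (within the scatter), so across compounds 2, 3 and 4 the number does not follow the size of the group. Nothing measured here accounts for this outcome.

As far as these compounds go, it remains open whether an amine, a carboxylic acid or a longer plain carbon chain at this position would match compound 3 or compound 4.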